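A few compounds are considered here, and "the series" means these few. Any claim that something is new, unique, unknown or untested is made for them only; others in the source may bear on it.

Compound 3 `COc1cc(C(=O)N2CCC(O)CC2)cc2nc(NCc3cccc(Cl)c3)oc12` stands second highest of the three numbers in an assay on isolated protein for inhibition of thyroid hormone receptor beta (Homo sapiens), read by fluorescence, with a stated time of 30 min (a lower number here means a stronger inhibitor, a higher number a weaker inhibitor), where compound 3 gives 352 nM; compound 1 `CCCN(CC1CCOC1)C(=O)c1cc(C)c2oc(NCc3cccc(Cl)c3)nc2c1` gives 35 nM and compound 2 `CCCc1cc(C(=O)N(CCC)CC2CCOC2)cc2nc(NCc3cccc(Cl)c3)oc12` gives 957 nM. Among the compounds with values here, the one measured step, a 27-fold higher number from compound 1 to compound 2 (1.44 log units; beyond the scatter), concerns a substituent on the core and not the amide. Compound 4 `CCC1CC(O)C(C)CN1C(=O)c1cc(OC)c2oc(NCc3cccc(Cl)c3)nc2c1` differs from compound 3 by 2-ethyl-4-hydroxy-5-methylpiperidin-1-yl in place of 4-hydroxypiperidin-1-yl on a carbonyl carbon. Within the data shown here, no measured step touches the amide side, so nothing seen here sets the direction, and the change is expected to stay near the scatter. Compound 4 is therefore estimated at 400 nM, with a range of 120 nM to 1300 nM, which would mean an expected step of a 1.1-fold higher number from compound 3 to compound 4 (0.06 log units; within the scatter).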

Compound 4, half-maximal inhibitory concentration: 13 nM
Compound 4: the middle estimate sits 31-fold (1.49 log units) above what was measured, and the stated range ends above it.
By their numbers in this assay, from the lowest: compound 4; then compound 1; then compound 3; then compound 2.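

Within the data shown here, the step of a 27-fold lower number from compound 3 to compound 4 (1.43 log units; beyond the scatter) shows that the amide side, which no earlier step touched, also moves the number in this assay beyond the scatter. The entering ring keeps the ring type and the hydrogen-bond donor and acceptor counts of 4-hydroxypiperidin-1-yl, and differs by its added ethyl and methyl groups. No evidence is available that explains the change. The compounds shown leave open whether the ethyl, the methyl or both together carry this step, and whether a propyl chain or an amine in place of the hydroxyl on this ring would keep it.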